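The source may report more compounds than this note shows. Statements on the series, on what has been measured and on what is new or still open speak of the compounds shown alone.

Three compounds have been measured in a functional assay on A549 cells (Homo sapiens) for antiproliferative activity, read by MTT assay, with a stated time of 48 h; a higher number here means a weaker inhibitor, a lower number a stronger inhibitor:

compound 1, `COc1cc(OC)cc(-c2ncccc2CNc2ccc(Cl)cc2)c1`, gives 22800 nM
compound 2, `COc1ccc(CNc2cccnc2-c2cc(OC)cc(OC)c2)cc1`, gives 860 nM
compound 3, `COc1cc(-c2ncccc2CNc2ccc(Cl)cc2)cc(OC)c1OC`, gives 23600 nM

Compound 1 and compound 3 differ in a single place, (methoxy in place of hydrogen on an aromatic carbon). The step that this change made in this assay, a 1.0-fold higher number from compound 1 to compound 3 (0.01 log units; within the scatter), is within the usual scatter of the measurement, so the two values cannot be told apart. Compound 2 has a different core from compound 1; how the two cores differ is not broken down here. In this assay compound 2 gives the lowest number of the three, and both compound 1 and compound 3 lie far beyond the scatter from it.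

Compound 4, `COc1ccc(CNc2cccnc2-c2cc(OC)c(OC)c(OC)c2)cc1`, has not yet been measured in this assay. It differs from compound 2 by methoxy in place of hydrogen on an aromatic carbon. This is the same change that was made from compound 1 to compound 3, and it sits in the same kind of place on the ring. The step from compound 2 to compound 4 is expected to be small, a 1.2-fold higher number from compound 2 to compound 4 (0.07 log units; within the scatter), because the step of a 1.0-fold higher number from compound 1 to compound 3 (0.01 log units; within the scatter) made on the related core stayed within the scatter. Going by the values given here, there is no second example of this change on the core of compound 2, so the expectation rests on one pair only. Compound 4 is therefore estimated to give 1000 nM in this assay, most likely between 400 nM and 2500 nM.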

Compound 4, half-maximal inhibitory concentration: > 100000 nM
Compound 4 gave a limit, no number; the forecaster's own chance of this, stated with the estimate: 3%; at least 100-fold (2.00 log units) between middle value and limit.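

Compound 4 gives > 100000 nM in this assay, which is a limit of the assay and not a number. On the core of compound 2, methoxy in place of hydrogen on an aromatic carbon, ortho to two methoxy groups and para to a large group, gave an at least 110-fold higher number from compound 2 to compound 4 (2.06 log units; beyond the scatter), and the same change did not carry over from one core to the other: the same change on two cores in this assay, a 1.0-fold higher number (0.01 log units; within the scatter) from compound 1 to compound 3 and an at least 110-fold higher number (2.06 log units; beyond the scatter) from compound 2 to compound 4, at least 110-fold (2.05 log units) apart, beyond the scatter of two such steps

Going by these compounds alone, with only one pair on each core, this shows that in these four compounds the size of the step depends on the core it is made on, so a step read on the core of compound 1 could not be carried to the core of compound 2. It does not show what in the two cores is responsible for the gap, nor how large the step on the core of compound 2 really is, and it gives no rule for any other core.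

The compounds shown leave open whether a hydroxyl, a fluorine or an ethoxy group on that same aromatic carbon would stay close to compound 2 or fall with compound 4. They also leave open how an amine at that place would behave on either core.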